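Methyl for nitro: the same step on a second core

The source may report more compounds than this note shows. Statements on the series, on what has been measured and on what is new or still open speak of the compounds shown alone.

Compound 2 `O=c1nc(-c2ccccc2[N+](=O)[O-])ss1` and compound 1 `Cc1ccccc1-c1nc(=O)ss1` share one core and differ in a single place, (methyl in place of nitro on an aromatic carbon). In an ADME assay on L02 cells (Homo sapiens) for inhibition, read by MTT assay, with a stated time of 48 h, tested at 100 uM (a lower number here means less inhibition, a higher number more inhibition at the concentration tested (going by the name of the read-out)), compound 2 gives 33%, and compound 1 gives 18.6%; the step is a number 14.4 percentage points lower from compound 2 to compound 1 (beyond the scatter). Compound 3 `O=c1oc(-c2ccccc2[N+](=O)[O-])ns1` is built on a different core; the difference between the two cores is not broken down here. In this assay compound 3 gives 32.4%, a number within the scatter of compound 2 and beyond the scatter above compound 1. Compound 4 `Cc1ccccc1-c1nsc(=O)o1` has not been measured. It differs from compound 3 as methyl in place of nitro on an aromatic carbon, and the place is the same word for word as in the pair from compound 2 to compound 1, so this is the same change made a second time, on the other core. Compound 3 starts at the same level as compound 2, so the step is expected to be about a number 13.4 percentage points lower from compound 3 to compound 4 (beyond the scatter), resting on the measured pair that gave a number 14.4 percentage points lower from compound 2 to compound 1 (beyond the scatter). Compound 4 is expected at 19%, estimated between 8% and 30%.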

Compound 4, a percentage reported as inhibition, at one concentration (the size of the read-out at that concentration, not a potency): 18.1%
The estimate for compound 4 lay 0.9 percentage points above the measured number, within the range that was stated.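

The step in this assay is a number 14.3 percentage points lower from compound 3 to compound 4 (beyond the scatter) for methyl in place of nitro on an aromatic carbon. Set beside the earlier step, the change carries from one core to the other with its size unchanged: the same change on two cores in this assay, a number 14.4 percentage points lower (beyond the scatter) from compound 2 to compound 1 and a number 14.3 percentage points lower (beyond the scatter) from compound 3 to compound 4, 0.1 percentage points apart, within the scatter of two such steps. Going by these compounds alone, this rests on only two pairs, one swap and a single concentration, so it supports transfer between these two cores for this swap alone; it gives no potency and no explanation for the step, and it sets no rule for other changes.

The compounds shown leave open whether a step of this size appears with other groups at the same place, such as an amine or a carboxylic acid in place of nitro, or a longer chain in place of methyl. They also leave open whether the same swap holds on a third core, or with further groups on the six-membered aromatic ring.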